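Bromo for methoxy on the shared core

The source may hold more compounds than are shown below. What is called first, only, known or untested is meant among the compounds shown, and "the series" means these compounds.

compound 1 `CCCCCCOS(=O)(=O)NC(=O)Nc1c(C(C)C)cccc1C(C)C`: 27000 nM
compound 2 `COc1cc(C(C)C)c(OC(=O)NS(=O)(=O)Oc2c(C(C)C)cccc2C(C)C)c(C(C)C)c1`: > 25000 nM

In an assay on liver for inhibition of sterol O-acyltransferase 1 (Rattus norvegicus), using microsomes (a lower number here means a stronger inhibitor, a higher number a weaker inhibitor), compound 1 gives 27000 nM, a measured number. Compound 2 gives no number in this assay: its value is a limit, > 25000 nM. Compound 2 therefore stands at the edge of what this assay reports, as shown by the limit of > 25000 nM in this assay, at which 1 of the 2 values shown sits. Between compound 1 and compound 2 no step is computed; the two values show only that compound 1 is read as a number while compound 2 is not.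

Compound 3 `CC(C)c1cc(Br)cc(C(C)C)c1OC(=O)NS(=O)(=O)Oc1c(C(C)C)cccc1C(C)C` has not been measured. It differs from compound 2 by bromo in place of methoxy on an aromatic carbon. Neither compound carries a measured step that would tell how this assay responds to a change at that position, so the step is expected to lie within the scatter, with no clear direction. Compound 3 is therefore expected to sit near compound 2, the estimated step being a number no higher from compound 2 to compound 3 (the limit leaves the size open). For compound 3 the estimate in this assay is 25000 nM, between 8000 nM and 80000 nM, with a considerable chance that only a limit is reported.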

Compound 3, half-maximal inhibitory concentration: 31000 nM
Beside the measured number, compound 3's estimate is 1.2-fold (0.09 log units) below it, and the stated range covers the measured number.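

In this assay no step can be read for bromo in place of methoxy between compound 2 and compound 3, because compound 2 is given only as a limit: the limit of > 25000 nM in this assay, at which 1 of the 3 values shown sits.

The compounds shown leave open whether this change on the shared core shifts the result in this assay at all, and in which direction.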